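The compounds below may be only part of what the source reports. "The series", "measured", "known", "first", "only" and "open" are said of these compounds alone.

Measured so far in an ADME assay on L929 cells (Mus musculus) for antiproliferative activity, read by CCK-8 assay, with a stated time of 48 h; a lower number here means a stronger inhibitor, a higher number a weaker inhibitor:

Compound 1 `CCCCSc1n[nH]c(-n2[se]c3ccccc3c2=O)n1` gives 30400 nM in this assay.
Compound 2 `Cc1ccccc1CSc1n[nH]c(-n2[se]c3ccccc3c2=O)n1` gives 15600 nM in this assay.

Among the compounds with values here, compound 2 carries the lower of the two numbers in this assay, but its only neighbour is compound 1, and the single measured step, a 1.9-fold lower number from compound 1 to compound 2 (0.29 log units; within the scatter), lies within the scatter, so the two compounds cannot be told apart on these data.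

Compound 3 `CC(C)Sc1n[nH]c(-n2[se]c3ccccc3c2=O)n1` has not yet been measured in this assay. Its change from compound 2: isopropyl in place of 2-methylbenzyl on a sulfur. Within the data shown here, the one measured step that bears on this is the reverse move from a short alkyl to the 2-methylbenzyl group, a 1.9-fold lower number from compound 1 to compound 2 (0.29 log units; within the scatter), which stayed within the scatter. Going back to a short alkyl, here isopropyl, should therefore undo at most that small difference; the expected step is a 1.6-fold higher number from compound 2 to compound 3 (0.20 log units; within the scatter), a number close to that of compound 1 and not beyond the scatter from compound 2. Compound 3 is thus expected at about 25000 nM, within a range of 10000 nM to 60000 nM.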

Compound 3, half-maximal inhibitory concentration: 37100 nM
Compound 3: middle estimate off by 1.5-fold (0.17 log units), on the low side; the range from low to high includes it.
By their numbers in this assay, from the lowest: compounds 2, 1 and 3 (each within the scatter of the next, the first and the last beyond it).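

Within this assay the group on a sulfur now shows its first step beyond the scatter: isopropyl in place of 2-methylbenzyl gives a 2.4-fold higher number from compound 2 to compound 3 (0.38 log units; beyond the scatter) and so counts as a real but modest change at this position. The short alkyl groups do not separate, as isopropyl in place of butyl gives a 1.2-fold higher number from compound 1 to compound 3 (0.09 log units; within the scatter) and leaves these two compounds indistinguishable, while compound 2 is resolved from compound 3 but not from compound 1, so the series does not yet show a clean split between 2-methylbenzyl and short alkyl groups. No measurement at hand offers an explanation for the step from compound 2 to compound 3.

The compounds shown leave open whether the aromatic ring of the 2-methylbenzyl group, its methyl group or simply its larger carbon count goes with the lower number, a question that an unsubstituted benzyl or a cyclohexylmethyl group on the sulfur would address. They also leave open how a longer alkyl chain, or a chain ending in an amine or a carboxylic acid, would read at this position.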